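Cyclohexyl to Propyl on the Amine Side Chain

The compounds below may be only part of what the source reports. "The series", "measured", "known", "first", "only" and "open" are said of these compounds alone.

Measured compounds:
compound 1, `c1ccc(CN2CCC3(CCCc4sccc43)CC2)cc1`, 10.5 nM
compound 2, `c1cc2c(s1)CCCC21CCN(CC2CCCCC2)CC1`, 4.3 nM

Of the compounds shown here, two sharing one core have been measured in an assay on Cerebral cortex for displacement of a labelled ligand from Sigma non-opioid intracellular receptor 1 (Cavia porcellus), read by scintillation counting, with a stated time of 120 min; on this read-out higher numbers stand for weaker inhibition and lower numbers for stronger inhibition. Compound 1 gives 10.5 nM, and compound 2 gives 4.3 nM. Among the measured compounds shown here, the only measured step, a 2.4-fold lower number from compound 1 to compound 2 (0.39 log units; beyond the scatter), came from placing cyclohexyl in place of phenyl on a saturated chain carbon bound to an amine nitrogen in a ring. Compound 2 therefore stands with the lower of the two numbers, ahead of compound 1 by a modest margin that lies beyond the scatter.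

Compound 3, `CCCCN1CCC2(CCCc3sccc32)CC1`, has not yet been measured in this assay. Its change from compound 2 is propyl in place of cyclohexyl on a saturated chain carbon bound to an amine nitrogen in a ring, so the ring-bearing side group is shortened to a plain chain. For the measured compounds named here, no measured step shows this kind of exchange; the one step in hand swapped one ring for another and moved the number only modestly. Going by the values given here, a small to modest rise in the number is expected, since the group that leaves is the one that carried the best number so far. The step from compound 2 to compound 3 is estimated at a 2.8-fold higher number from compound 2 to compound 3 (0.45 log units; beyond the scatter). Compound 3 is expected to give about 12 nM, within 4 nM to 40 nM.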

Compound 3, inhibition constant: 6.3 nM
Beside the measured number, compound 3's estimate is 1.9-fold (0.28 log units) above it; low and high end bracket the measured number.
By their numbers in this assay, from the lowest: compounds 2, 3 and 1 (each within the scatter of the next, the first and the last beyond it).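

Among the compounds shown here, until now every compound carried a ring at this position, so the one measured step could only compare one ring with another. In this assay, propyl in place of cyclohexyl gives a 1.5-fold higher number from compound 2 to compound 3 (0.17 log units; within the scatter), and propyl in place of phenyl gives a 1.7-fold lower number from compound 1 to compound 3 (0.22 log units; within the scatter), both within the scatter. A plain chain with no ring therefore cannot be told apart from either ring-bearing group, even though compound 1 and compound 2 differ from each other beyond the scatter, so among these compounds a ring on the saturated chain carbon bound to an amine nitrogen in a ring is not needed to keep the number in this range.

No evidence is available that would explain this result. The compounds shown leave open how far this tolerance extends, for instance whether a longer chain, or a hydroxyl group or a carboxylic acid at the end of the propyl, would keep the number in the same range in this assay.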